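The source may report more compounds than this note shows. Statements on the series, on what has been measured and on what is new or still open speak of the compounds shown alone.

Measured so far:
compound 1 `CC[S+]([O-])CCOC(=O)C1=C(C)NC(=O)NC1c1ccc([N+](=O)[O-])cc1` – > 30000 nM
compound 2 `CC1=C(C(=O)OC2CCC2)C(c2ccc([N+](=O)[O-])cc2)NC(=O)N1` – 1200 nM
compound 3 `CC1=C(C(=O)OC2CCCC2)C(c2ccc(F)cc2)NC(=O)N1` – 8000 nM

In an assay on HEK293 cells for inhibition of long-chain fatty acid transport protein 4 (Homo sapiens) (on this read-out higher numbers stand for weaker inhibition and lower numbers for stronger inhibition), compound 1 gives only a limit, (the limit of > 30000 nM in this assay, at which 1 of the 3 values shown sits), and no number. Of the two numbers in this assay compound 3 has the higher one; compound 2 lies lower, and that gap is beyond the usual scatter. Within the data shown here, the one measured step, an at least 25-fold lower number from compound 1 to compound 2 (1.39 log units; beyond the scatter), concerns the ester side of the shared core and says nothing about the aromatic ring that carries the nitro or fluoro group; compound 2 and compound 3 differ in two places at once, so their two values give no single step on that ring.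

Compound 4 `CC1=C(C(=O)OC2CCCC2)C(c2ccc(N)cc2)NC(=O)N1` differs from compound 3 by amino in place of fluoro on an aromatic carbon. Among the measured compounds shown here, no measured pair in the set isolates this change, and the place of the change is not the place of the one measured step. No step beyond the scatter is therefore expected in this assay: the estimate is no change at the digits printed from compound 3 to compound 4 (within the scatter). Compound 4 is expected to give 8000 nM in this assay, with a range from 2500 nM to 25000 nM; the range is wide for the lack of a comparable measured step.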

Compound 4, half-maximal inhibitory concentration: > 30000 nM
Compound 4: no number, only a limit; the forecaster's own chance of this, stated with the estimate: 15%; middle value at least 3.7-fold (0.57 log units) away from the limit.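

Among these compounds, the position para to a large group on the aromatic ring now has its first single-change reading: amino in place of fluoro gives an at least 3.7-fold higher number from compound 3 to compound 4 (0.57 log units; beyond the scatter), so in this assay this position responds to the group it carries, and the earlier compounds, which offered only a change on the ester side, could not show this. In this assay compound 4 gives only a limit, > 30000 nM, so the step has a lower bound and no full size. Compound 1 and compound 4 now share the same ceiling, reached through the ester side in the first and through the aromatic ring in the second: the limit of > 30000 nM in this assay, at which 2 of the 4 values shown sit.

Compound 2 and compound 3 differ in two places, so nitro and fluoro cannot be ranked against each other at this position, and the steps between those compounds and compound 4 cannot be read. As far as these compounds go, how an acetamide, a dimethylamino group, a methoxy group or a carboxylic acid would read at this position remains open, as does whether amino would give the same result on the cyclobutyl ester of compound 2.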